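Carboxy to chloro on the shared core: clearance notes

The source may hold more compounds than are shown below. What is called first, only, known or untested is meant among the compounds shown, and "the series" means these compounds.

Measured so far:
- compound 1 (`Cc1c(COc2cccc(OCC3CCOCC3)c2)[nH]c2ccc(C(=O)O)cc2c1=O`): < 20 mL/min/kg (a limit)
- compound 2 (`COC(C)(C)CCOc1cccc(OCc2[nH]c3ccccc3c(=O)c2C)c1`): > 1000 mL/min/kg (a limit)
- compound 3 (`Cc1c(COCCCCO)[nH]c2ccccc2c1=O`): "not determined" (no result reported) (no result)

In an in vitro ADME assay on microsomes from liver (Homo sapiens) for metabolic stability, tested at 0.2 uM (a higher number here means faster removal of the compound, a lower number slower removal), compound 1 stands at < 20 mL/min/kg and this is a limit, not a number. It is the lowest entry among the results in hand. Compound 2 gives > 1000 mL/min/kg at the opposite end, also a limit. Compound 3 is recorded as "not determined" (no result reported) and adds nothing to the comparison.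

Compound 4 (`Cc1c(COc2cccc(OCC3CCOCC3)c2)[nH]c2ccc(Cl)cc2c1=O`) carries chloro in place of carboxy on an aromatic carbon and is otherwise the same as compound 1. Among the measured compounds shown here, no measured pair differs in one place, so no direct precedent for this change exists in this assay and the expectation is only approximate.

A clear rise is expected because compound 2 without a carboxy group gives > 1000 mL/min/kg as a limit. The estimated change runs an at least 10-fold higher number from compound 1 to compound 4 (1.00 log units; beyond the scatter) as an expected upward step. For compound 4 the expected clearance is 200 mL/min/kg within an estimated range from 50 mL/min/kg to 800 mL/min/kg as a working figure.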

Compound 4, clearance: > 1000 mL/min/kg
Compound 4: a limit, no number; the forecaster's own chance of this, stated with the estimate: 20%; middle value at least 5.0-fold (0.69 log units) away from the limit.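

In this assay, among the compounds shown here, compound 1 and compound 4 form the first pair that differs in one place, so the group on this aromatic carbon of the shared core can now be read on its own. Chloro in place of carboxy gives an at least 50-fold higher number from compound 1 to compound 4 (1.69 log units; beyond the scatter), which shows that the clearance read-out responds strongly to this single change while the rest of the structure stays the same. Neither end of this step is a number, and the upper end is a limit shared with another entry: the limit of > 1000 mL/min/kg in this assay, at which 2 of the 4 values shown sit.

The full size of the step cannot be read from the two limits, and a single pair gives no account of why clearance differs, nor whether the carboxy group or the chloro carries more of the difference. Also open, as far as these compounds go, is where other groups at this position, such as a nitrile, a primary amide or an amine, would fall relative to these two limits, and whether the same exchange gives a step of this size with a different side chain on the shared core.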